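The source may report more compounds than this note shows. Statements on the series, on what has been measured and on what is new or still open speak of the compounds shown alone.

Series notes. Compound 3 `COc1ccc(-c2cc3c(OC)cc(OC)cc3n(C)c2=O)cc1` has been measured in a functional assay on PC-3 cells (Homo sapiens) for cytotoxicity, read by colorimetric assay and MTT assay (on this read-out higher numbers stand for weaker inhibition and lower numbers for stronger inhibition), where compound 3 gives 10000 nM. That value is level with compound 1 `COc1ccc(-c2cc3c(OC)ccc(OC)c3nc2O)cc1`, which in this assay gives 10000 nM, and with compound 2 `COc1cc(OC)c2cc(-c3ccc(OCc4ccccc4)cc3)c(O)nc2c1`, which in this assay gives 10000 nM; neither gap exceeds the scatter, so no order among the three can be read from these numbers.

Compound 4 `COc1ccc(-c2cc3c(OC)cc(OC)cc3n(CC#N)c2=O)cc1` has not yet been measured. It differs from compound 3 by cyano in place of hydrogen on a saturated chain carbon bound to an aromatic nitrogen. Going by the values given here, no measured pair in this set shows the effect of such a change. Since compound 3 gives 10000 nM in this assay and both other compounds sit at the same level, the step from compound 3 to compound 4 is expected to be no change at the digits printed from compound 3 to compound 4 (within the scatter), none beyond the scatter. Compound 4 is therefore estimated at 10000 nM in this assay, within 4000 nM to 25000 nM.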

Compound 4, half-maximal inhibitory concentration: 10000 nM
For compound 4 middle estimate and measured number coincide at the digits printed; measured number inside the range.
By their numbers in this assay, from the lowest: compounds 1, 2, 3 and 4 (each within the scatter of the next).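

In this assay, going by these compounds alone, the only single-place step reads no change at the digits printed from compound 3 to compound 4 (within the scatter) for cyano in place of hydrogen on a saturated chain carbon bound to an aromatic nitrogen. The same difference read as methyl to cyanomethyl thus leaves the value within the scatter, which compound 1 and compound 2 could not show, as neither forms a single-place pair with compound 3. No evidence on the cause accompanies this result.

Going by these compounds, whether an amine, a carboxylic acid or a longer chain at this place would move the value stays open.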